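The compounds below may be only part of what the source reports. "The series", "measured", "known", "first", "only" and "open" are said of these compounds alone.

Measured so far in a functional assay on SNB-75 cells (Homo sapiens) for inhibition, read by sulforhodamine B assay, with a stated time of 48 h, tested at 10 uM; a higher number here means more inhibition at the concentration tested (going by the name of the read-out), a lower number less inhibition:
compound 1 `c1ccc(-c2cn3ccnc3c(-c3ccc4ncn(C5CCCCC5)c4c3)n2)cc1`: 44.4%
compound 2 `O=Cc1ccc(-c2cn3ccnc3c(-c3ccc4ncn(C5CCCCC5)c4c3)n2)cc1`: 21.4%
compound 3 `c1ccc2c(-c3cn4ccnc4c(-c4ccc5ncn(C6CCCCC6)c5c4)n3)cccc2c1`: 16.5%

Compound 2 stands second highest of the three numbers. Its nearest neighbour is compound 3, the gap being a number 4.9 percentage points lower from compound 2 to compound 3 (within the scatter), within the scatter, so no order between those two can be claimed. For the measured compounds named here, the only step among the three that lies beyond the scatter is a number 23 percentage points lower from compound 1 to compound 2 (beyond the scatter); the other measured step, a number 27.9 percentage points lower from compound 1 to compound 3 (beyond the scatter), also ran downward and is likewise beyond the scatter.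

Compound 4 `Clc1ccc(-c2cn3ccnc3c(-c3ccc4ncn(C5CCCCC5)c4c3)n2)cc1` has not yet been measured. It differs from compound 2 by chloro in place of formyl on an aromatic carbon. Going by the values given here, the one measured step that bears on this change is a number 23 percentage points lower from compound 1 to compound 2 (beyond the scatter), which introduced the formyl group that now leaves. Among the compounds with values here, no measured step places a chloro group anywhere, so the entering group is untested here. On the strength of that single step, removal of the formyl points back toward the number of compound 1, but with the chloro group unknown the expectation is only a modest rise with a wide range. For compound 4 the expected value in this assay is 34%, between 14% and 54%, an expected step of a number 12.6 percentage points higher from compound 2 to compound 4 (beyond the scatter).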

Compound 4, a percentage reported as inhibition, at one concentration (the size of the read-out at that concentration, not a potency): 31.2%
Estimate against measurement, compound 4: 2.8 percentage points above; low and high end bracket the measured number.
By their numbers in this assay, from the lowest: compounds 3, 2 and 4 (each within the scatter of the next, the first and the last beyond it); then compound 1.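

In this assay, the step of a number 13.2 percentage points lower from compound 1 to compound 4 (beyond the scatter) shows that, para to a large group, a second substituent besides formyl also gives a lower number than hydrogen, and neither of the two goes against this. The data draw no line between these two substituents: a number 9.8 percentage points higher from compound 2 to compound 4 (within the scatter) leaves chloro and formyl unseparated at this position. The 4-chlorophenyl compound does separate from the naphthalen-1-yl compound, with a number 14.7 percentage points higher from compound 3 to compound 4 (beyond the scatter) in this assay, which compound 2 did not do, its gap to compound 3 lying within the scatter.

No measurement here gives a reason for any of these steps. On these data alone, whether an amine, a methoxy group or a carboxylic acid at this position would also stay under the number of compound 1 remains open.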